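The source may hold more compounds than are shown below. What is called first, only, known or untested is meant among the compounds shown, and "the series" means these compounds.

Measured so far:
- compound 1 `Nc1ccccc1/N=C\c1cc(=O)oc2cc(OCc3ccccc3)ccc12`: 9250 nM
- compound 2 `O=c1cc(/C=N\Nc2ccc([N+](=O)[O-])cc2[N+](=O)[O-])c2c(OCc3ccccc3)cc(OCc3ccccc3)cc2o1`: "not active" (no number reported)

Within the data shown here, in a functional assay, read by spectrophotometry, with a stated time of 3 min (a lower number here means a stronger inhibitor, a higher number a weaker inhibitor), compound 1 gives 9250 nM, the only number in this set. Among the measured compounds shown here, compound 2 carries no number, so no step between measured compounds can be drawn from these two. Compound 3 `O=c1cc(/C=N\c2ccc(O)cc2)c2ccc(OCc3ccccc3)cc2o1` differs from compound 1 in one place: 4-hydroxyphenyl in place of 2-aminophenyl on a double-bonded nitrogen. For the measured compounds named here, with no measured step to lean on, the change is expected to move the result little, if at all, beyond the usual scatter; the expected step of a 1.0-fold lower number from compound 1 to compound 3 (0.01 log units; within the scatter) is small. Compound 3 is therefore estimated at about 9000 nM, within a range from 2500 nM to 35000 nM.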

Compound 3, half-maximal inhibitory concentration: 64500 nM
Estimate against measurement, compound 3: 7.2-fold (0.86 log units) below; the measured number lies above the stated range.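

The group on the double-bonded nitrogen clearly matters in this assay: replacing 2-aminophenyl with 4-hydroxyphenyl gives a 7.0-fold higher number from compound 1 to compound 3 (0.84 log units; beyond the scatter) and leaves compound 3 the weaker inhibitor. The two groups have the same counts of heavy atoms, hydrogen-bond donors and hydrogen-bond acceptors, so those counts alone do not predict this step. No measurement shown here explains it.

Still open, going by these compounds, is whether the swap of nitrogen for oxygen or the different numbered ring position drives the step. Also open, on these data alone, is how a carboxylic acid or a morpholine would compare at this position.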